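Swapping the ethylphenyl ether for an indolyl ether

A few compounds are considered here, and "the series" means these few. Any claim that something is new, unique, unknown or untested is made for them only; others in the source may bear on it.

Compound 1, `Brc1ccccc1OC1CCN(c2ccc(-n3ccnc3)nn2)CC1`, gives 5 nM in an assay on microsomes from liver for inhibition of acyl-CoA desaturase 1 (Rattus norvegicus); a lower number here means a stronger inhibitor, a higher number a weaker inhibitor.
Compound 2, `FC(F)(F)c1ccccc1OC1CCN(c2ccc(-n3ccnc3)nn2)CC1`, gives 4 nM in this assay.
Compound 3, `CCc1ccccc1OC1CCN(c2ccc(-n3ccnc3)nn2)CC1`, gives 4 nM in this assay.

Compound 3 sits level with compound 2 (no change at the digits printed from compound 2 to compound 3 (within the scatter)) and within the usual scatter of compound 1 (a 1.3-fold lower number from compound 1 to compound 3 (0.10 log units; within the scatter)). Compound 4, `c1cc(OC2CCN(c3ccc(-n4ccnc4)nn3)CC2)c2cc[nH]c2c1`, carries 1H-indol-4-yl in place of 2-ethylphenyl on an oxygen on a saturated carbon. Within the data shown here, no measured step exchanges the whole aromatic group on that oxygen; the steps of a 1.3-fold lower number from compound 1 to compound 2 (0.10 log units; within the scatter), a 1.3-fold lower number from compound 1 to compound 3 (0.10 log units; within the scatter) and no change at the digits printed from compound 2 to compound 3 (within the scatter) each exchange only one group on the ring, and all three stay within the scatter, so this assay has so far been indifferent to what sits on that ring. The change to compound 4 is larger than any of those, and a modest rise in the number is expected, a 3.0-fold higher number from compound 3 to compound 4 (0.48 log units; beyond the scatter). Compound 4 is estimated at 12 nM, between 3 nM and 50 nM.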

Compound 4, half-maximal inhibitory concentration: 162 nM
For compound 4 the middle estimate is 14-fold (1.13 log units) below the measured one, outside the stated range (above it).
By their numbers in this assay, from the lowest: compounds 2, 3 and 1 (each within the scatter of the next); then compound 4.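

The aromatic group on the oxygen is not a free choice in this assay: single-group swaps on the ring stayed within the scatter, but exchanging the whole group gives a large step (a 41-fold higher number from compound 3 to compound 4 (1.61 log units; beyond the scatter)). The same holds when 1H-indol-4-yl replaces 2-bromophenyl (a 32-fold higher number from compound 1 to compound 4 (1.51 log units; beyond the scatter)). Nothing available explains this rise.

Going by these compounds, whether it goes with the hydrogen-bond donor of 1H-indol-4-yl or with its five-membered ring stays open. So does how an amine or a carboxylic acid on the phenyl ring would read.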